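A few compounds are considered here, and "the series" means these few. Any claim that something is new, unique, unknown or untested is made for them only; others in the source may bear on it.

In a functional assay on FM3A cells (Mus musculus) for cytotoxicity (a lower number here means that less compound is needed, a higher number that more compound is needed for the effect), compound 1 `c1ccc(C23CCCC(OOC(C4CCCCC4)OO2)O3)cc1` gives 10000 nM and compound 2 `CCC(CC)C1OOC2CCCC(c3ccccc3)(OO1)O2` gives 33000 nM, so compound 2 holds the higher of the two numbers. Not yet measured is compound 3 `Fc1ccc(C2OOC3CCCC(c4ccccc4)(OO2)O3)cc1`, in which 4-fluorophenyl stands in place of pentan-3-yl on a saturated ring carbon (4-fluorophenyl in place of pentan-3-yl on a saturated ring carbon). Among the compounds with values here, only one measured step bears on this change: a 3.3-fold higher number from compound 1 to compound 2 (0.52 log units; beyond the scatter), where pentan-3-yl replaced cyclohexyl at that same carbon. Compound 3 carries a six-membered ring there again, as compound 1 does at 10000 nM, but an aromatic one, and no such group has been measured at this place, so the guide is loose. A step of similar or smaller size towards a lower number in this assay is therefore expected, namely a 2.1-fold lower number from compound 2 to compound 3 (0.31 log units; beyond the scatter). For compound 3 the estimated value is 16000 nM, with an expected range of 6000 nM to 45000 nM.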

Compound 3, half-maximal effective concentration: 17000 nM
Beside the measured number, compound 3's estimate is 1.1-fold (0.03 log units) below it; measured number inside the range.
By their numbers in this assay, from the lowest: compounds 1, 3 and 2 (each within the scatter of the next, the first and the last beyond it).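

At the saturated ring carbon between two ring oxygen atoms, an aromatic group now appears, and in this assay it does not separate from either saturated group: the exchange for pentan-3-yl gives a 1.9-fold lower number from compound 2 to compound 3 (0.29 log units; within the scatter), and the exchange for cyclohexyl gives a 1.7-fold higher number from compound 1 to compound 3 (0.23 log units; within the scatter). Among these three compounds, the only step beyond the scatter remains a 3.3-fold higher number from compound 1 to compound 2 (0.52 log units; beyond the scatter), so 4-fluorophenyl, with its six-membered aromatic ring, is tolerated here without a clear shift in either direction. No evidence at hand bears on why these numbers fall as they do.

The compounds shown leave open what the fluorine contributes, as unsubstituted phenyl at this carbon is not among them. They also leave open whether an amine or a carboxylic acid on that aromatic ring would move the number beyond the scatter.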